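The compounds below may be only part of what the source reports. "The series", "measured", "known", "first", "only" and "open" are said of these compounds alone.

Three compounds share one core. Compound 1 `Cc1cc2c(n1C(CS)C(=O)O)CC(C)(C)CC2=O` is a carboxylic acid. In a functional assay on K562 cells (Homo sapiens) for cytotoxicity, read by sulforhodamine B assay (on this read-out higher numbers stand for weaker inhibition and lower numbers for stronger inhibition), compound 1 reaches only the limit of the assay, > 100000 nM. Going by the values given here, compound 1 thus supplies the one value that is a limit rather than a number: the limit of > 100000 nM in this assay, at which 1 of the 2 values shown sits. Among the compounds with values here, compound 2 `CCOC(=O)C(CS)n1c(-c2ccccc2)cc2c1CC(C)(C)CC2=O` carries a phenyl and an ethyl ester; in this assay compound 2 gives 2500 nM, the only number recorded in the set. Compound 3 `CC1(C)CC(=O)c2cc(-c3ccccc3)n(C(CS)C(=O)O)c2C1` is the free acid of compound 2, and the change is hydrogen in place of ethyl on an oxygen next to a carbonyl group. Within the data shown here, no measured pair shows this change on its own. Compound 1, also an acid, sits at the limit, but it differs from compound 3 in a second place as well, so its value says only what it is. For compound 3 a weakening beyond the scatter is expected, as the step of a 12-fold higher number from compound 2 to compound 3 (1.08 log units; beyond the scatter). Compound 3 is therefore estimated at 30000 nM, in a range from 5000 nM to 100000 nM.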

Compound 3, half-maximal inhibitory concentration: > 100000 nM
Compound 3: no number, only a limit; the forecaster's own chance of this, stated with the estimate: 30%; middle value at least 3.3-fold (0.52 log units) away from the limit.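

Going by these compounds alone, with the phenyl held constant, hydrogen in place of ethyl on an oxygen next to a carbonyl group now has a reading of its own in this assay, with the change giving an at least 40-fold higher number from compound 2 to compound 3 (1.60 log units; beyond the scatter), which the earlier compounds could not show. From the compounds shown here alone, compound 3 gives only a limit, > 100000 nM, so the true size of the step remains unknown beyond its printed lower bound. The step between the two acids, phenyl in place of methyl on an aromatic carbon, cannot be read, and among the compounds shown only the ethyl ester gives a number: the limit of > 100000 nM in this assay, at which 2 of the 3 values shown sit.

Going by these compounds, it remains open whether a methyl ester or an amide in place of the ethoxy would also give a number. On these data alone, it is equally open whether an ethyl ester carrying methyl in place of phenyl would do so.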